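The source may report more compounds than this note shows. Statements on the series, on what has been measured and on what is new or still open speak of the compounds shown alone.

Compound 1 `O=C(Nc1cccc(-c2oc3cc(-c4ccc(F)cc4)ccc3c(=O)c2O)c1)c1ccc(Cl)cc1`: 4030 nM
Compound 2 `O=C(Nc1cccc(-c2oc3cc(-c4ccc(F)cc4)ccc3c(=O)c2O)c1)c1ccc(F)cc1F`: 6980 nM
Compound 3 `Cc1cccc(C(=O)Nc2cccc(-c3oc4cc(-c5ccc(F)cc5)ccc4c(=O)c3O)c2)c1`: 8030 nM

In a functional assay on HCC1937 cells (Homo sapiens) for antiproliferative activity, read by CCK-8 assay, with a stated time of 72 h (on this read-out higher numbers stand for weaker inhibition and lower numbers for stronger inhibition), compound 1 carries the lowest of the three numbers, but this says little: the step of a 1.7-fold higher number from compound 1 to compound 2 (0.24 log units; within the scatter) and the step of a 2.0-fold higher number from compound 1 to compound 3 (0.30 log units; within the scatter) are both within the scatter, so the three measured compounds cannot be told apart on these numbers. Compound 4 `Cc1cc(C)cc(C(=O)Nc2cccc(-c3oc4cc(-c5ccc(F)cc5)ccc4c(=O)c3O)c2)c1` has not yet been measured and differs from compound 1 in one place: 3,5-dimethylphenyl in place of 4-chlorophenyl on a carbonyl carbon. Among the compounds with values here, the measured step that comes closest to this change is the one from compound 1 to compound 3, where a 3-methylphenyl also took the place of the 4-chlorophenyl on the carbonyl carbon, and that step stayed within the scatter. The step from compound 1 to compound 2, another swap of the group on the carbonyl carbon, was likewise within the scatter. Within the data shown here, nothing measured so far suggests that changing the group on this carbonyl carbon moves the number by much. For compound 4 the expected step is therefore a 1.7-fold higher number from compound 1 to compound 4 (0.24 log units; within the scatter), a small rise that need not reach beyond the scatter. Compound 4 is estimated at 7000 nM, with a likely range from 3500 nM to 14000 nM.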

Compound 4, half-maximal inhibitory concentration: 4860 nM
The estimate for compound 4 lay 1.4-fold (0.16 log units) above the measured number, within the range that was stated.
By their numbers in this assay, from the lowest: compounds 1, 4, 2 and 3 (each within the scatter of the next).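

In this assay, the new comparison is a second methyl group on the ring: methyl in place of hydrogen on an aromatic carbon gives a 1.7-fold lower number from compound 3 to compound 4 (0.22 log units; within the scatter), so one methyl and two methyls cannot be told apart here. The 3,5-dimethylphenyl group, with 8 heavy atoms against 7 in 4-chlorophenyl and no halogen, shows a 1.2-fold higher number from compound 1 to compound 4 (0.08 log units; within the scatter), and set against the 2,4-difluorophenyl group it shows a 1.4-fold lower number from compound 2 to compound 4 (0.16 log units; within the scatter), so all four groups on this carbonyl carbon now sit within the scatter of one another. Nothing measured here offers an explanation for this flat picture.

Going by these compounds, all four compounds carry a six-membered aromatic ring of carbon only on this carbonyl carbon, so it remains open whether a pyridine ring, an amine, a carboxylic acid or a longer alkyl chain at this place would move the number beyond the scatter. The shared core is the same in all four compounds, so these numbers also say nothing about what a change there would do.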